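This account rests on a few compounds, and the source may have more. Where it says the series, first, only, none or still open, it means among the compounds named here.

Measured compounds: compound 1 `COc1ccc(/C=N/NC(=O)c2ccc(C)cc2O)cc1`, compound 2 `Cc1ccc(C(=O)N/N=C/c2ccccc2)c(O)c1`, compound 3 `Cc1ccc(C(=O)N/N=C/c2ccccc2O)c(O)c1`.

In an ADME assay on cells (Mus musculus, strain BALB/C) for cytotoxicity, read by MTT assay, with a stated time of 24 h (a lower number here means that less compound is tolerated, a higher number that more compound is tolerated), compound 1 gives 723000 nM, compound 2 gives 578000 nM, and compound 3 gives 761000 nM. All three numbers lie within the scatter of one another, as the steps of a 1.3-fold lower number from compound 1 to compound 2 (0.10 log units; within the scatter) and a 1.3-fold higher number from compound 2 to compound 3 (0.12 log units; within the scatter) show, so compound 2 stands apart from neither neighbour.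

Compound 4 `Cc1ccc(C(=O)N/N=C/c2cccc(F)c2)c(O)c1` differs from compound 2 by fluoro in place of hydrogen on an aromatic carbon. The two measured steps each swap one small group on the same ring of the shared core, and neither moved this assay beyond the scatter; a single fluoro should behave alike. No step beyond the scatter is therefore expected for the step of a 1.0-fold higher number from compound 2 to compound 4 (0.02 log units; within the scatter). Compound 4 is estimated at 600000 nM, with a range from 350000 nM to 1000000 nM.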

Compound 4, half-maximal cytotoxic concentration: 166000 nM
For compound 4 the middle estimate is 3.6-fold (0.56 log units) above the measured one; measured number below the stated range.
By their numbers in this assay, from the lowest: compound 4; then compounds 2, 1 and 3 (each within the scatter of the next).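

In this assay the swap of hydrogen for fluoro on an aromatic carbon, meta to a large group, gives a 3.5-fold lower number from compound 2 to compound 4 (0.54 log units; beyond the scatter) and is the only step among these compounds to pass the scatter. This shows that this ring of the shared core does not tolerate every small change equally: one fluorine atom moved the number, while the methoxy and hydroxy swaps on the same ring did not. Nothing at hand explains this difference.

On these data alone, whether chloro or methyl at this place would shift the number similarly remains open. So does whether fluoro elsewhere on this ring would give the same step.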